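From hydroxymethyl to methoxy on compound 2

The source may hold more compounds than are shown below. What is called first, only, known or untested is meant among the compounds shown, and "the series" means these compounds.

Of the compounds shown here, two have been tested so far in a functional assay on HepG2 cells (Homo sapiens) for cytotoxicity, read by MTT assay, with a stated time of 48 h; on this read-out higher numbers stand for weaker inhibition and lower numbers for stronger inhibition. Compound 1 `COCCCN1C(/C=C/c2ccc(O)cc2)=CC(=O)CC1c1ccc(O)cc1` reads > 100000 nM, which is a limit of the assay and not a number. Going by the values given here, compound 2 `O=C(/C=C(/C=C/c1ccc(O)cc1)NCCCO)/C=C/c1ccc(O)cc1` gives 54100 nM, the only actual number available, so nothing yet places it within a series of measured values. The next compound, compound 3 `COCCNC(=C\C(=O)/C=C/c1ccc(O)cc1)/C=C/c1ccc(O)cc1`, contains the same atoms as compound 2, joined differently: methoxy in place of hydroxymethyl on a saturated chain carbon, two bonds along the chain from an amine nitrogen. In words, methoxy stands in place of hydroxymethyl on a saturated chain carbon, two bonds along the chain from an amine nitrogen, so that (3-hydroxypropyl)amino becomes (2-methoxyethyl)amino. Among the compounds with values here, no measured step shows how such a change moves the results in this assay, so the only anchor is compound 2 at 54100 nM. The expected step of a 1.1-fold higher number from compound 2 to compound 3 (0.04 log units; within the scatter) is small, with no shift beyond the usual scatter and only a slight lean towards weaker inhibition. Compound 3 is estimated at 60000 nM, with an expected range of 25000 nM to 100000 nM.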

Compound 3, half-maximal inhibitory concentration: 63300 nM
Compound 3: middle estimate off by 1.1-fold (0.02 log units), on the low side; the measured number falls inside the stated range.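

In this assay, going by these compounds alone, replacing (3-hydroxypropyl)amino with (2-methoxyethyl)amino gives a 1.2-fold higher number from compound 2 to compound 3 (0.07 log units; within the scatter), the first measured step at this position. The swap removes the hydrogen-bond donor of the hydroxymethyl group and keeps the same atoms in a different arrangement, yet the two readings cannot be told apart on this test, so this hydrogen-bond donor is not needed to keep the reading of compound 2. The readings of both compounds also lie under a ceiling set by the test, which bounds how much weaker any further change could be shown to be: the limit of > 100000 nM in this assay, at which 1 of the 3 values shown sits.

The change from 3-hydroxypropyl to 2-methoxyethyl alters the end group and the chain together, so this single step cannot show what either alteration does alone. As far as these compounds go, it also remains open whether an amine or a carboxylic acid in place of hydroxymethyl, or a longer chain, would shift the number beyond the usual scatter, and in which direction.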